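The source may hold more compounds than are shown below. What is called first, only, known or untested is meant among the compounds shown, and "the series" means these compounds.

Measured so far:
compound 1 `COCCCN1CCC(O)(CNC(=O)c2nc(C(C)C)n3ccccc23)CC1` gives 316 nM in a functional assay on CHO cells for agonist activity at 5-hydroxytryptamine receptor 4 (Homo sapiens), read by a luciferase reporter and cAMP accumulation, with a stated time of 4 h; a higher number here means that more compound is needed for the effect, a lower number that less compound is needed
compound 2 `CC(C)c1nc(-c2nnc(C3CCN(C4CCC4)CC3)o2)c2ccccn12` gives 840 nM in this assay

Compound 2 stands at the higher of the two numbers; compound 1 sits at a lower number, and that gap lies beyond the usual scatter. Compound 3 `CC(C)c1nc(-c2nnc(C3CCN(C(C)C)CC3)o2)c2ccccn12` is not yet measured. It differs from compound 2 by isopropyl in place of cyclobutyl on an amine nitrogen in a ring. For the measured compounds named here, no step between measured compounds shows a change of this kind, so nothing here sets its size or direction. The expected step in this assay is a 1.1-fold lower number from compound 2 to compound 3 (0.02 log units; within the scatter), none beyond the scatter. Compound 3 is thus estimated at 800 nM, with a range from 300 nM to 2500 nM.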

Compound 3, half-maximal effective concentration: 500 nM
Beside the measured number, compound 3's estimate is 1.6-fold (0.20 log units) above it; the measured number falls inside the stated range.
By their numbers in this assay, from the lowest: compounds 1, 3 and 2 (each within the scatter of the next, the first and the last beyond it).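

For the compounds shown here, on an amine nitrogen in a ring, isopropyl in place of cyclobutyl gives a 1.7-fold lower number from compound 2 to compound 3 (0.23 log units; within the scatter) in this assay, the first reading of a change at this position. For this one pair, the open-chain group and the four-membered ring of carbon only cannot be told apart. No measured evidence accounts for the step. On these data alone, whether a longer chain such as n-butyl or a benzyl group on that nitrogen would give a step beyond the scatter remains open. So does whether the same exchange behaves alike on the core of compound 1.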